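The source may report more compounds than this note shows. Statements on the series, on what has been measured and on what is new or still open speak of the compounds shown alone.

In a functional assay on MCF7 cells (Homo sapiens) for inhibition, read by MTT assay, with a stated time of 72 h (a lower number here means a stronger inhibitor, a higher number a weaker inhibitor), compound 1, `CN(C(=O)NC(=O)c1ccc(F)c(F)c1)c1nc(C(F)(F)F)c(C(=O)N/N=C/c2cc(C(F)(F)F)cc(C(F)(F)F)c2)s1`, gives 2.61 ug/mL, the lowest of the two numbers recorded in this set. Compound 3, `CN(C(=O)NC(=O)c1cccc(C(F)(F)F)c1)c1nc(C(F)(F)F)c(C(=O)N/N=C/c2ccc(C(F)(F)F)cc2)s1`, gives 6.5 ug/mL, a higher number whose gap from compound 1 lies beyond the usual scatter. Compound 2, `CNc1nc(C(F)(F)F)c(C(=O)N/N=C/c2ccc(C(F)(F)F)cc2)s1`, reaches only a limit of the assay, > 100 ug/mL, and so supplies no number; this is the case described by the limit of > 100 ug/mL in this assay, at which 1 of the 3 values shown sits. Compound 4, `CN(C(=O)NC(=O)c1ccc(Cl)cc1Cl)c1nc(C(F)(F)F)c(C(=O)N/N=C/c2cc(C(F)(F)F)cc(C(F)(F)F)c2)s1`, has not yet been measured in this assay. Its difference from compound 1 is 2,4-dichlorophenyl in place of 3,4-difluorophenyl on a carbonyl carbon; the change sits on the carbonyl carbon whose other neighbour is an amide-type nitrogen, and the rest of the molecule is untouched. Within the data shown here, no measured pair in this set isolates such a swap, so there is no direct guide to its size. The step from compound 1 to compound 4 is expected to be small, with no clear direction and likely within the scatter, as a 1.1-fold higher number from compound 1 to compound 4 (0.06 log units; within the scatter). Compound 4 is therefore estimated at 3 ug/mL, within a range of 1.2 ug/mL to 8 ug/mL.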

Compound 4, half-maximal inhibitory concentration: > 100 ug/mL
Compound 4: no number, only a limit; the forecaster's own chance of this, stated with the estimate: 5%; middle value at least 33-fold (1.52 log units) away from the limit.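

In this assay, among these compounds, the swap of 3,4-difluorophenyl for 2,4-dichlorophenyl on the carbonyl carbon gives an at least 38-fold higher number from compound 1 to compound 4 (1.58 log units; beyond the scatter), the first sign that the group at this place can decide whether the compound registers a usable number at all. The two groups match in heavy atom count, ring type, hydrogen-bond donors and acceptors, and charge, so those counts do not predict the outcome here. Compound 4 gives only a limit of the assay and not a number, so the full size of the step stays unknown: the limit of > 100 ug/mL in this assay, at which 2 of the 4 values shown sit.

The change alters both the halogen and its place on the ring, and the compounds shown do not separate the two. A 3,4-dichlorophenyl or 2,4-difluorophenyl group on the same carbonyl carbon would be needed to tell them apart.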